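Methyl step on the side chain, compound 3 to compound 4

The source may report more compounds than this note shows. Statements on the series, on what has been measured and on what is new or still open speak of the compounds shown alone.

Measured in an ADME assay on Huh-7 cells (Homo sapiens) for cytotoxicity, with a stated time of 72 h (a lower number here means that less compound is tolerated, a higher number that more compound is tolerated), each value a limit:
compound 1 `CCC(C)(C)Cn1nc(-c2cccs2)c(O)c(C2=NS(=O)(=O)c3cc(NS(C)(=O)=O)ccc3N2)c1=O` gives > 1000 nM
compound 2 `COC(C)(C)CCn1nc(-c2cccs2)c(O)c(C2=NS(=O)(=O)c3cc(NS(C)(=O)=O)ccc3N2)c1=O` gives > 33000 nM
compound 3 `CCCC(C)n1nc(-c2cccs2)c(O)c(C2=NS(=O)(=O)c3cc(NS(C)(=O)=O)ccc3N2)c1=O` gives > 33000 nM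

Compound 3 sits at the limit of > 33000 nM in this assay, at which 2 of the 3 values shown sit, and has no exact number. Compound 4 `CC(C)CC(C)n1nc(-c2cccs2)c(O)c(C2=NS(=O)(=O)c3cc(NS(C)(=O)=O)ccc3N2)c1=O` differs from it by methyl in place of hydrogen on a saturated chain carbon bound to two saturated chain carbons. The nearest measured changes to this chain are a step that the two limits leave unreadable from compound 2 to compound 3 and a step that the two limits leave unreadable from compound 1 to compound 3, and neither gives a size; nor does a step that the two limits leave unreadable from compound 1 to compound 2 in the same series. No step beyond the scatter is therefore expected, and no direction can be given. The expected change is a number no higher from compound 3 to compound 4 (the limit leaves the size open) in this assay for now. The estimated value for compound 4 is 33000 nM with an expected range from 10000 nM to 60000 nM and probably only a limit reported.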

Compound 4, half-maximal cytotoxic concentration: > 33000 nM
Compound 4 was reported as a limit (the forecaster's own chance of this, stated with the estimate: 90%); the middle value sits exactly at the limit.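

For the compounds shown here, compound 4, like compound 1, compound 2 and compound 3, is reported only as a limit in this assay, so no step between compound 4 and any of the others can be read. Whether these side chains differ at all in this assay stays open, as none of the compounds shown has an exact value.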